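The compounds below may be only part of what the source reports. "The series", "measured", "known", "first", "only" and "open" are said of these compounds alone.

Measured compounds:
- compound 1 `CC[C@H](CCn1cncn1)c1ccc(Cl)cc1` gives 57 ug/mL in an ADME assay on RD cells (Homo sapiens) for cytotoxicity, read by MTT assay, with a stated time of 3 days; on this read-out higher numbers stand for lower toxicity in this test and lower numbers for higher toxicity in this test
- compound 2 `CC[C@H](CCn1cncn1)c1ccc(C)cc1` gives 85.2 ug/mL in this assay

For the measured compounds named here, compound 1 stands as the lower of the two numbers measured so far, with compound 2 next to it; the single measured step, a 1.5-fold higher number from compound 1 to compound 2 (0.17 log units; within the scatter), is within the scatter, so the two values cannot be told apart.

Compound 3 `CCCC[C@H](CCn1cncn1)c1ccc(Cl)cc1` is not yet measured. It differs from compound 1 in one place: ethyl in place of hydrogen on a saturated chain carbon, three bonds along the chain from an aromatic carbon. Going by the values given here, the only measured step concerns an exchange on an aromatic carbon and leaves the chain untouched, so nothing measured bears directly on a lengthening of the chain. Among the compounds with values here, with no step in the set beyond the scatter, and no comparison on the chain at all, the step from compound 1 is expected to be none beyond the scatter, and a 1.1-fold lower number from compound 1 to compound 3 (0.06 log units; within the scatter) expresses that expectation as a small move. The estimate for compound 3 in this assay is therefore 50 ug/mL, expected within a range from 22 ug/mL to 110 ug/mL.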

Compound 3, half-maximal cytotoxic concentration: 20.3 ug/mL
Beside the measured number, compound 3's estimate is 2.5-fold (0.39 log units) above it; measured number below the stated range.
By their numbers in this assay, from the lowest: compound 3; then compounds 1 and 2 (each within the scatter of the next).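

In this assay the saturated chain proves to be a place where the number can move: ethyl in place of hydrogen on a saturated chain carbon, three bonds along the chain from an aromatic carbon, gives a 2.8-fold lower number from compound 1 to compound 3 (0.45 log units; beyond the scatter) and so points to higher toxicity in this test. The only earlier exchange, methyl in place of chloro on an aromatic carbon, gave a 1.5-fold higher number from compound 1 to compound 2 (0.17 log units; within the scatter) and could not separate its two compounds, so this modest change on the chain is the first step shown to lie beyond the scatter, resting on a single pair of compounds. Nothing measured here accounts for the step.

The compounds shown leave open whether the number would follow chain length at this place, with a propyl or a hexyl chain, and whether an amine on the chain would behave like the added ethyl. They also leave open whether the same lengthening would give a similar step on the core of compound 2, which carries methyl in place of chloro.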